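This account rests on a few compounds, and the source may have more. Where it says the series, first, only, none or still open, it means among the compounds named here.

Among the measured compounds shown here, compound 1 `CCCNc1nc(-c2ccccc2)nc2c1nnn2Cc1ccccc1F` stands with the lower of the two numbers so far in an assay on isolated protein for binding affinity to adenosine receptor A1 (Bos taurus) (a lower number here means a stronger inhibitor, a higher number a weaker inhibitor), where compound 1 gives 3200000 nM. For the measured compounds named here, its nearest neighbour, compound 2 `CCCNc1nc(-c2ccccc2)nc2c1nnn2Cc1ccccc1`, gives 37000000 nM, and the only measured step, a 12-fold higher number from compound 1 to compound 2 (1.06 log units; beyond the scatter), concerns hydrogen in place of fluoro on an aromatic carbon. Compound 3 `CCCCCCNc1nc(-c2ccccc2)nc2c1nnn2Cc1ccccc1F` differs from compound 1 by propyl in place of hydrogen on a saturated chain carbon, three bonds along the chain from a nitrogen on an aromatic ring, so that the propyl of compound 1 becomes a hexyl. Going by the values given here, no measured step touches this chain; the fluoro-to-hydrogen step from compound 1 to compound 2 says nothing about it. Lacking any guide, the reviewer expects no step beyond the scatter in this assay, with a wide range. Compound 3 is estimated at 3200000 nM, between 800000 nM and 13000000 nM, an expected step of no change at the digits printed from compound 1 to compound 3 (within the scatter).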

Compound 3, inhibition constant: 25000000 nM
Compound 3: middle estimate off by 7.8-fold (0.89 log units), on the low side, and the stated range ends below it.
By their numbers in this assay, from the lowest: compound 1; then compounds 3 and 2 (each within the scatter of the next).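

In this assay, the chain on the nitrogen proves sensitive to length: the change from propyl to hexyl gives a 7.8-fold higher number from compound 1 to compound 3 (0.89 log units; beyond the scatter) and so counts against the longer chain, which the fluoro-to-hydrogen step could not show. With the fluoro present in both compounds, the propyl of compound 1 is the better of the two chain lengths shown. Nothing measured here explains this step.

As far as these compounds go, whether the number climbs gradually through butyl and pentyl or changes abruptly at one length stays open, as does whether ethyl or a branched chain such as isobutyl would match the propyl. Also open, from the compounds shown here alone, is whether a chain carrying an amine or a hydroxyl would behave as hexyl does.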